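Swapping the Cyclohexyl Amine Substituent for a Hydroxypropyl Chain

This account rests on a few compounds, and the source may have more. Where it says the series, first, only, none or still open, it means among the compounds named here.

Measured so far:
compound 1 `CNc1ncc(-c2cccc(Cl)c2)c(-c2ccccc2)n1`: 75%
compound 2 `Clc1cccc(-c2cnc(NC3CCCCC3)nc2-c2ccccc2)c1`: 58%

Both compounds share one core and were tested in an assay on CHO cells for displacement of a labelled ligand from adenosine receptor A1 (Homo sapiens), read by scintillation counting, with a stated time of 1 h, tested at 1 uM; a higher number here means more inhibition at the concentration tested (going by the name of the read-out), a lower number less inhibition. Compound 2 stands lowest of the two numbers, and its nearest neighbour is compound 1. Going by the values given here, the single measured step, a number 17 percentage points lower from compound 1 to compound 2 (beyond the scatter), is modest but lies beyond the scatter, so the larger group on the nitrogen went with less inhibition.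

Compound 3 `OCCCNc1ncc(-c2cccc(Cl)c2)c(-c2ccccc2)n1` has not yet been measured. Its change from compound 2 is 3-hydroxypropyl in place of cyclohexyl on a nitrogen on an aromatic ring: the cyclohexyl leaves and a 3-hydroxypropyl enters, on a nitrogen on an aromatic ring whose other neighbour is an aromatic carbon. Among the compounds with values here, the only step that bears on this is a number 17 percentage points lower from compound 1 to compound 2 (beyond the scatter), in which the cyclohexyl arrived and the number fell. Because that step was a number 17 percentage points lower from compound 1 to compound 2 (beyond the scatter), removing the cyclohexyl again is expected to recover part of the loss, though the 3-hydroxypropyl is not the methyl of compound 1, so a full return is not expected. The expected step is a number 8 percentage points higher from compound 2 to compound 3 (within the scatter). Compound 3 is therefore estimated at 66%, with a range from 46% to 84%.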

Compound 3, a percentage reported as inhibition, at one concentration (the size of the read-out at that concentration, not a potency): > 80%
Compound 3 ended at the assay's limit (the forecaster's own chance of this, stated with the estimate: 3%); middle value at least 14 percentage points away from the limit.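

In this assay compound 3 gives > 80%, which is a limit of the assay and not an exact number: the limit of > 80% in this assay, at which 1 of the 3 values shown sits.

Replacing the cyclohexyl with a 3-hydroxypropyl on this nitrogen gives a number at least 22 percentage points higher from compound 2 to compound 3 (beyond the scatter), so the earlier fall, a number 17 percentage points lower from compound 1 to compound 2 (beyond the scatter), does not mean that every group bigger than methyl on this nitrogen goes with less inhibition. The comparison with the methyl gives a number at least 5 percentage points higher from compound 1 to compound 3 (that floor lies within the scatter), so the 3-hydroxypropyl and the methyl cannot be put in order here, and the open chain with its hydroxyl is simply shown to be compatible with strong inhibition at this position.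

Still open, from the compounds shown here alone, is whether the hydroxyl matters at all or whether losing the cyclohexyl ring is enough, a question that a plain propyl chain on the same nitrogen would help to settle. Going by these compounds, it also remains unknown how far this position stretches, for instance to a longer chain ending in a hydroxyl or to a chain ending in an amine or a carboxylic acid.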